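A few compounds are considered here, and "the series" means these few. Any claim that something is new, unique, unknown or untested is made for them only; others in the source may bear on it.

Measured so far:
Compound 1, `CC1(C)CC(NC(=O)C(C)(O)C(F)(F)F)c2cc(-c3ccc(Cl)cc3)c(-c3ccc(Cl)cc3Cl)nc2O1`: -27%
Compound 2, `CC1(C)C[C@@H](NC(=O)c2ccccc2O)c2cc(-c3ccc(Cl)cc3)c(-c3ccc(Cl)cc3Cl)nc2O1`: -25%

In a functional assay on the whole organism with Rattus norvegicus as the target, with a stated time of 18 h, at a dose of 3 mg/kg by the oral route (a lower number here means a stronger effect, a higher number a weaker effect of the compound at the dose given), compound 1 gives -27%, and compound 2 gives -25%. Compound 1 stands at the low end of these two numbers, but compound 2 lies within the usual scatter of it, so the two cannot be told apart on this evidence. Among the measured compounds shown here, no single-change pair between measured compounds is available, so the account rests on the values themselves.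

Compound 3, `CC1(C)CC(NC(=O)C2(O)CC2)c2cc(-c3ccc(Cl)cc3)c(-c3ccc(Cl)cc3Cl)nc2O1`, has not yet been measured in this assay. It differs from compound 1 in one place: 1-hydroxycyclopropyl in place of 1-hydroxy-1-(trifluoromethyl)ethyl on a carbonyl carbon. Both groups keep one hydroxyl, and the change is confined to the acyl end of the amide. Compound 3 is therefore expected to stay close to compound 1, with a step of a number 7 percentage points higher from compound 1 to compound 3 (within the scatter) that is estimated as a slight weakening, not clearly beyond the scatter. In this assay compound 3 is estimated at -20%, with a range from -45% to 5%.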

Compound 3, a percentage reported as activity, at one dose (the size of the read-out at that dose, not a potency): -74%
The estimate for compound 3 lay 54 percentage points above the measured number; the whole stated range lies above it.
By their numbers in this assay, from the lowest: compound 3; then compounds 1 and 2 (each within the scatter of the next).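

In this assay, the acyl end of the amide proves to be a place where a single change matters: 1-hydroxycyclopropyl in place of 1-hydroxy-1-(trifluoromethyl)ethyl on a carbonyl carbon gives a number 47 percentage points lower from compound 1 to compound 3 (beyond the scatter), a stronger effect at the dose given that the two earlier compounds, inseparable within the scatter, gave no sign of. Both groups carry a hydroxyl, so this step belongs to the exchange as a whole, in which the trifluoromethyl leaves and a three-membered ring enters, and this one step cannot divide it between the two. No measurement available here accounts for the size of the step.

Going by these compounds, whether the hydroxyl is needed remains open, as a plain cyclopropyl or a 1-aminocyclopropyl group at this place would show. On these data alone, whether the ring size matters, as 1-hydroxycyclobutyl would test, also remains open.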